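From methoxycarbonyl to trifluoromethyl on the shared core

The compounds below may be only part of what the source reports. "The series", "measured", "known", "first", "only" and "open" are said of these compounds alone.

In an ADME assay on BJ cells (Homo sapiens) for cytotoxicity, with a stated time of 72 h (on this read-out lower numbers stand for an effect already at smaller amounts and higher numbers for an effect only at larger amounts of compound), compound 1 `Cc1cc(NC(=O)Nc2ccc(C(C)(C)C)cc2)c2ccccc2n1` gives 20000 nM. Compound 3 `COC(=O)c1ccc(NC(=O)Nc2cc(C)nc3ccccc23)cc1` gives 21000 nM, and the two sit close together, with a 1.1-fold higher number from compound 1 to compound 3 (0.02 log units; within the scatter). Compound 2 `CSc1ccc(NC(=O)Nc2cc(C)nc3ccccc23)cc1` reads > 25000 nM, which is a limit of the assay and not a number.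

Compound 4 `Cc1cc(NC(=O)Nc2ccc(C(F)(F)F)cc2)c2ccccc2n1` keeps the shared core and carries trifluoromethyl in place of methoxycarbonyl on an aromatic carbon, para to a large group (trifluoromethyl in place of methoxycarbonyl on an aromatic carbon). The closest guides are the other swaps at this place, which replace one group with another on the same core. Besides the step already given, they show an at least 1.2-fold higher number from compound 1 to compound 2 (0.09 log units; that floor lies within the scatter) and an at least 1.1-fold lower number from compound 2 to compound 3 (0.07 log units; that floor lies within the scatter). Neither of these two steps is shown to exceed the scatter, though both rest on the limit of compound 2. Trifluoromethyl itself has not been measured here, so some uncertainty remains.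

In this assay, no step beyond the scatter is expected, with an estimated 1.2-fold lower number from compound 3 to compound 4 (0.07 log units; within the scatter). For compound 4 the estimated value is 18000 nM, with an expected range of 9000 nM to 30000 nM.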

Compound 4, half-maximal effective concentration: > 25000 nM
Compound 4 ended at the assay's limit (the forecaster's own chance of this, stated with the estimate: 30%); middle value at least 1.3-fold (0.14 log units) from the limit.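

Trifluoromethyl, on an aromatic carbon para to a large group, gives a second compound whose reading in this assay stops at the end of the scale and is not a number: the limit of > 25000 nM in this assay, at which 2 of the 4 values shown sit. Against the compounds with real numbers, the change gives an at least 1.1-fold higher number from compound 3 to compound 4 (0.07 log units; that floor lies within the scatter) and an at least 1.2-fold higher number from compound 1 to compound 4 (0.09 log units; that floor lies within the scatter), so the four groups shown at this place, including tert-butyl and methoxycarbonyl, have produced no step shown to exceed the scatter. The step between compound 2 and compound 4 cannot be read, as both values are limits.

From the compounds shown here alone, it remains open whether an amine, a carboxylic acid or a longer chain at this place would give a clearly lower number. Going by these compounds, how far the true values of compound 2 and compound 4 lie past the limit also remains open.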